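Swapping the triazole substituent in a 4-aminoquinoline series

The compounds below may be only part of what the source reports. "The series", "measured", "known", "first", "only" and "open" are said of these compounds alone.

Compound 1 `CN(CCNCc1cn(-c2cccc(Cl)c2)nn1)CCNc1ccnc2cc(Cl)ccc12`: 17000 nM
Compound 2 `CN(CCNCc1cn(-c2nc3ccccc3[nH]2)nn1)CCNc1ccnc2cc(Cl)ccc12`: 33000 nM

In a functional assay on NCI-H460 cells (Homo sapiens) for antiproliferative activity, read by sulforhodamine B assay, with a stated time of 72 h (a lower number here means a stronger inhibitor, a higher number a weaker inhibitor), compound 1 gives 17000 nM and compound 2 gives 33000 nM. For the measured compounds named here, compound 2 has the higher of the two numbers, but the only measured step, a 1.9-fold higher number from compound 1 to compound 2 (0.29 log units; within the scatter), lies within the scatter, so the two cannot be ranked. Compound 3 `CN(CCNCc1cn(CCCn2nn[nH]c2=O)nn1)CCNc1ccnc2cc(Cl)ccc12` differs from compound 2 by a group of 9 heavy atoms (4 carbon, 4 nitrogen, 1 oxygen; one five-membered aromatic ring with 4 hetero atoms) in place of a group of 9 heavy atoms (7 carbon, 2 nitrogen; one five-membered aromatic ring with 2 hetero atoms, one six-membered aromatic ring of carbon only), on an aromatic nitrogen. Going by the values given here, the single measured step at this position was small, so no change beyond the scatter is expected here. Compound 3 is expected to give 35000 nM in this assay, with a range from 12000 nM to 100000 nM, meaning an estimated step of a 1.1-fold higher number from compound 2 to compound 3 (0.03 log units; within the scatter).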

Compound 3, half-maximal inhibitory concentration: > 200000 nM
Compound 3: no number, only a limit; the forecaster's own chance of this, stated with the estimate: 15%; middle value at least 5.7-fold (0.75 log units) from the limit.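

Compound 3 gives no number in this assay, only a limit: the limit of > 200000 nM in this assay, at which 1 of the 3 values shown sits.

Even so, its steps can be read: the new group brings an at least 6.0-fold higher number from compound 2 to compound 3 (0.78 log units; beyond the scatter) and an at least 11-fold higher number from compound 1 to compound 3 (1.07 log units; beyond the scatter). For the compounds shown here, this position on the aromatic nitrogen is therefore not indifferent to its group, although the one earlier step stayed within the scatter.

From the compounds shown here alone, since compound 3 gives only a limit, how far its activity really falls remains unknown, as does which part of the entering group matters. Going by these compounds, how a simple amine or a carboxylic acid would read at this position also stays open.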